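This account rests on a few compounds, and the source may have more. Where it says the series, first, only, none or still open, it means among the compounds named here.

Working notes on the series, read in a functional assay on MCF7 cells (Homo sapiens) for inhibition, read by sulforhodamine B assay, with a stated time of 72 h; on this read-out higher numbers stand for weaker inhibition of growth and lower numbers for stronger inhibition of growth. Within the data shown here, compound 1 (`CCOC(=O)/C=C/c1ccncc1-c1ccc2c(cnn2C)c1`) gives 7320 nM, the only number so far. Compound 2 (`O=C(O)/C=C/c1ccncc1-c1ccc2ccccc2c1`) stands at > 10000 nM, which is a limit and not a number. Compound 3 (`Cn1ncc2cc(-c3cnccc3/C=C/C(=O)O)ccc21`) gives > 10000 nM, also a limit. The reference point for the next step is therefore (the limit of > 10000 nM in this assay, at which 2 of the 3 values shown sit).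

Compound 4 (`NC(=O)/C=C/c1ccncc1-c1ccc2ccccc2c1`) is reached from compound 2 by amino in place of hydroxy on a carbonyl carbon, or carboxy to carbamoyl. Among the measured compounds shown here, the one measured step that touches a comparable carbonyl group is an at least 1.3-fold higher number from compound 1 to compound 3 (0.13 log units; that floor lies within the scatter). That step is only a floor within the scatter, it involves a different replacement, and the core of compound 3 differs from that of compound 2. It gives neither a size nor a direction for this change.

The expectation in this assay is no step beyond the scatter, with compound 4 staying close to the limit. Compound 4 is perhaps expected to return a number in the region of compound 1 at 7320 nM. For compound 4 the estimated value is 9000 nM, with an expected range of 3500 nM to 20000 nM. The estimate corresponds to an expected at least 1.1-fold lower number from compound 2 to compound 4 (0.04 log units; that floor lies within the scatter).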

Compound 4, concentration for 50% growth inhibition: > 10000 nM
Compound 4: a limit, no number; the forecaster's own chance of this, stated with the estimate: 55%; middle value at least 1.1-fold (0.04 log units) away from the limit.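

In this assay compound 4 gives > 10000 nM, which is a limit and not a number. Compound 2 also stands at a limit, so no step can be read between compound 2 and compound 4: the limit of > 10000 nM in this assay, at which 3 of the 4 values shown sit. The compounds shown leave open whether carboxy to carbamoyl changes inhibition of growth at all, in either direction.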